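Phenyl for pyridin-2-yl on the ring nitrogen

The source may hold more compounds than are shown below. What is called first, only, known or untested is meant among the compounds shown, and "the series" means these compounds.

compound 1 `COc1ccccc1OCCNCC(O)COc1ccc(-c2ccccc2)cc1` gives 6010 nM
compound 2 `OC(COc1ccc(-c2ccccc2)cc1)CN1CCN(c2ccccn2)CC1` gives 25000 nM

In a functional assay on SK-MEL-28 cells (Homo sapiens) for inhibition, read by MTT assay, with a stated time of 48 h (on this read-out higher numbers stand for weaker inhibition and lower numbers for stronger inhibition), compound 2 has the higher of the two numbers, and its gap to compound 1 lies beyond the scatter. Compound 3 `OC(COc1ccc(-c2ccccc2)cc1)CN1CCN(c2ccccc2)CC1` carries phenyl in place of pyridin-2-yl on an amine nitrogen in a ring. Among the compounds with values here, no measured pair covers this exchange, so the expectation rests on the structural change alone. A small move toward a lower number is expected in this assay and should stay within the scatter. The expected step is a 1.7-fold lower number from compound 2 to compound 3 (0.22 log units; within the scatter) and no larger one is foreseen. Compound 3 is estimated at 15000 nM (expected range 6000 nM to 35000 nM).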

Compound 3, half-maximal inhibitory concentration: 15300 nM
Compound 3: the middle estimate sits 1.0-fold (0.01 log units) below what was measured, and the stated range covers the measured number.
By their numbers in this assay, from the lowest: compound 1; then compounds 3 and 2 (each within the scatter of the next).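

In this assay, phenyl in place of pyridin-2-yl on the amine nitrogen in the ring gives a 1.6-fold lower number from compound 2 to compound 3 (0.21 log units; within the scatter) and so lies within the scatter. At this position, the ring nitrogen and the hydrogen-bond acceptor counted for pyridin-2-yl are therefore not required to keep the number at this level. Still open, from the compounds shown here alone, is whether a carboxylic acid or an amine on the phenyl, or a longer chain between the phenyl and the ring nitrogen, would move the number beyond the scatter. No measurement bears on why the two groups read alike.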